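Cytotoxicity notes on two anilide cores: ethyl to trifluoromethyl

A few compounds are considered here, and "the series" means these few. Any claim that something is new, unique, unknown or untested is made for them only; others in the source may bear on it.

Compound 1 `CCS(=O)(=O)Nc1ccc(NC(=O)c2ccc(Cl)c([N+](=O)[O-])c2)cc1OC` and compound 2 `COc1cc(NC(=O)c2ccc(Cl)c([N+](=O)[O-])c2)ccc1NS(=O)(=O)C(F)(F)F` differ in one place only: trifluoromethyl in place of ethyl on a sulfonyl sulfur. In an ADME assay on HEK293 cells (Homo sapiens) for cytotoxicity, read by MTT assay, with a stated time of 48 h (on this read-out lower numbers stand for stronger inhibition and higher numbers for weaker inhibition), compound 1 gives 63700 nM. Compound 2 reaches only the limit of this assay, > 250000 nM, so no number is known for it. The step is recorded as an at least 3.9-fold higher number from compound 1 to compound 2 (0.59 log units; beyond the scatter), and its size is bounded on one side only, since the value of compound 2 is the limit of > 250000 nM in this assay, at which 1 of the 3 values shown sits.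

Compound 3 `CCS(=O)(=O)Nc1ccc(NC(=O)c2cccc(C(F)(F)F)c2)cc1Cl` rests on a different core; the difference between the core of compound 3 and the core of compound 1 is not broken down here. In this assay, for the measured compounds named here, compound 3 gives 159000 nM, the highest of the two numbers known. Compound 4 `O=C(Nc1ccc(NS(=O)(=O)C(F)(F)F)c(Cl)c1)c1cccc(C(F)(F)F)c1` has not been measured. It differs from compound 3 by trifluoromethyl in place of ethyl on a sulfonyl sulfur; the place reads the same word for word as in the pair of compound 1 and compound 2, so this is the same change made a second time.

Since the same change gave an at least 3.9-fold higher number from compound 1 to compound 2 (0.59 log units; beyond the scatter), a step of the same direction is expected for compound 4, a 2.8-fold higher number from compound 3 to compound 4 (0.45 log units; beyond the scatter). Compound 4 is therefore estimated at 450000 nM, with a likely range of 160000 nM to 1200000 nM, and a result that stops at the limit of this assay is the more probable outcome.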

Compound 4, half-maximal inhibitory concentration: 210000 nM
Estimate against measurement, compound 4: 2.1-fold (0.33 log units) above; the measured number falls inside the stated range.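

On the core of compound 3, trifluoromethyl in place of ethyl on a sulfonyl sulfur gives a 1.3-fold higher number from compound 3 to compound 4 (0.12 log units; within the scatter) in this assay, so the clear step seen on the core of compound 1 does not repeat there, and its size does not carry from one core to the other: the same change on two cores in this assay, an at least 3.9-fold higher number (0.59 log units; beyond the scatter) from compound 1 to compound 2 and a 1.3-fold higher number (0.12 log units; within the scatter) from compound 3 to compound 4, at least 2.9-fold (0.47 log units) apart, beyond the scatter of two such steps

The value of compound 2 is a limit and not a number: the limit of > 250000 nM in this assay, at which 1 of the 4 values shown sits.

For the compounds shown here, the two pairs do not show which part of the difference between the cores goes with the gap between the steps, and with only two cores they give no general rule for this change across the series.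

From the compounds shown here alone, it remains open how the number in this assay responds when the sulfonyl sulfur carries a group other than ethyl or trifluoromethyl, such as methyl, a longer chain like butyl, or a phenyl ring. Going by these compounds, it is also open whether the two cores would separate more clearly with a single substituent exchanged at a time, for example a carboxylic acid or an amine in place of the nitro group on the core of compound 1.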